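A few compounds are considered here, and "the series" means these few. Any claim that something is new, unique, unknown or untested is made for them only; others in the source may bear on it.

Compound 1 `c1ccc(Cc2nnc3sc(-c4ccccc4Oc4ccccc4)nn23)cc1` is the point of departure. In a functional assay on the whole organism (strain Wistar) for inhibition, with Rattus norvegicus as the target, read by paw edema, with stated times of 30 min and 2 h, at a dose of 20 mg/kg by the oral route (on this read-out lower numbers stand for less inhibition and higher numbers for more inhibition at the one dose given (going by the name of the read-out)), compound 1 gives 41%, the higher of the two numbers recorded, while compound 2 `c1ccc(Cc2nnc3sc(Cc4cc5ccccc5[nH]4)nn23)cc1` gives 36.7% in this assay, a gap that stays within the usual scatter, so the two cannot be ranked. Compound 3 `c1ccc(OCc2nnc3sc(-c4ccccc4Oc4ccccc4)nn23)cc1` has not been measured in this assay. It differs from compound 1 by phenoxy in place of phenyl on a saturated chain carbon bound to an aromatic carbon. Among the compounds with values here, no measured pair shows this change, so no direction can be read from the data. The expected step of a number 1 percentage points lower from compound 1 to compound 3 (within the scatter) is therefore none beyond the scatter. Compound 3 is estimated at 40%, within a range of 25% to 55%.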

Compound 3, a percentage reported as inhibition, in the whole organism at one dose (the size of the read-out at that dose, not a potency): 54.8%
The estimate for compound 3 lay 14.8 percentage points below the measured number, and the stated range covers the measured number.
By their numbers in this assay, from the lowest: compounds 2 and 1 (each within the scatter of the next); then compound 3.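

Phenoxy in place of phenyl on a saturated chain carbon bound to an aromatic carbon gives, in this assay, a number 13.8 percentage points higher from compound 1 to compound 3 (beyond the scatter). Within the data shown here, this shows that the read-out responds to a change at this position, which the earlier compounds, differing from each other elsewhere, could not show. It rests on this single pair, so it applies only to the core of compound 1. Nothing available explains the step. On these data alone, whether an amine in place of the phenoxy oxygen, or a longer chain, would keep this gain stays open, as does whether the same change would carry over to compound 2.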